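Methyl in Place of Methoxy, Carried onto a Chloro Core

The source may hold more compounds than are shown below. What is called first, only, known or untested is meant among the compounds shown, and "the series" means these compounds.

Compound 1 `COc1ccc2nc(NC(=O)c3cn(-c4ccccc4)nc3-c3ccc(F)cc3)sc2c1` is measured in a functional assay on A549 cells (Homo sapiens) for cytotoxicity, read by MTT assay, with a stated time of 72 h; on this read-out higher numbers stand for weaker inhibition and lower numbers for stronger inhibition. Compound 1 gives > 50000 nM, which is a limit of this assay rather than a number. Compound 2 `Cc1ccc2nc(NC(=O)c3cn(-c4ccccc4)nc3-c3ccc(F)cc3)sc2c1` gives 24600 nM in this assay, and compound 3 `COc1ccc2nc(NC(=O)c3cn(-c4ccccc4)nc3-c3ccc(Cl)cc3)sc2c1` gives 31400 nM. The change from compound 1 to compound 2 is methyl in place of methoxy on an aromatic carbon, and it made an at least 2.0-fold lower number from compound 1 to compound 2 (0.30 log units; that floor lies within the scatter). The core of compound 3 differs from that of compound 1 by chloro in place of fluoro on an aromatic carbon, which made an at least 1.5-fold lower number from compound 1 to compound 3 (0.20 log units; that floor lies within the scatter). Compound 4 `Cc1ccc2nc(NC(=O)c3cn(-c4ccccc4)nc3-c3ccc(Cl)cc3)sc2c1`, not yet measured, differs from compound 3 by methyl in place of methoxy on an aromatic carbon, the same change as from compound 1 to compound 2. Resting on an at least 2.0-fold lower number from compound 1 to compound 2 (0.30 log units; that floor lies within the scatter), compound 4 is expected to show a 2.0-fold lower number from compound 3 to compound 4 (0.29 log units; within the scatter) in this assay. Compound 4 is thus estimated at 16000 nM, with a likely range from 6000 nM to 40000 nM.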

Compound 4, half-maximal inhibitory concentration: 18600 nM
Beside the measured number, compound 4's estimate is 1.2-fold (0.07 log units) below it, within the range that was stated.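

In this assay, methyl in place of methoxy gave a 1.7-fold lower number from compound 3 to compound 4 (0.23 log units; within the scatter), and chloro in place of fluoro gave a 1.3-fold lower number from compound 2 to compound 4 (0.12 log units; within the scatter). The methyl change thus shows nothing beyond the scatter on the core of compound 3, and it does not show that the size of the step is kept from one core to the other: the same change on two cores in this assay, an at least 2.0-fold lower number (0.30 log units; that floor lies within the scatter) from compound 1 to compound 2 and a 1.7-fold lower number (0.23 log units; within the scatter) from compound 3 to compound 4; the limit leaves it open whether they differ. The chloro change stands the same way, so neither change is shown to carry over as a firm effect: the same change on two cores in this assay, an at least 1.5-fold lower number (0.20 log units; that floor lies within the scatter) from compound 1 to compound 3 and a 1.3-fold lower number (0.12 log units; within the scatter) from compound 2 to compound 4; the limit leaves it open whether they differ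

The compounds shown leave open how an amine, a carboxylic acid or a longer chain on that aromatic carbon would read in this assay. They also leave open whether any such group would give a step beyond the scatter.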